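The source may report more compounds than this note shows. Statements on the series, on what has been measured and on what is new or still open speak of the compounds shown alone.

Working notes on the series. In an ADME assay on PBL cells (Homo sapiens) for cytotoxicity, read by MTT assay, with a stated time of 72 h (on this read-out higher numbers stand for weaker inhibition and lower numbers for stronger inhibition), compound 1 `COc1cc2c(Oc3ccc(NC(=O)N/N=C/c4ccc(O)cc4)cc3F)ccnc2cc1OCCCN1CCCCC1` is recorded as "not determined" (no result reported), and compound 2 `COc1cc2c(Oc3ccc(NC(=O)N/N=C/c4ccncc4)cc3F)ccnc2cc1OCCCN1CCCCC1` is recorded as "not determined" (no result reported); for both, no number was reported. Going by the values given here, compound 3 `COc1cc2c(Oc3ccc(NC(=O)N/N=C/c4cccs4)cc3F)ccnc2cc1OCCCN1CCCCC1` is therefore the only member of the set with a number: in this assay compound 3 gives 68700 nM. Among the compounds with values here, with no second number there is no step between measured compounds to lean on, and compound 3 stands alone rather than anywhere on a ranking.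

Compound 4 `COc1cc2c(Oc3ccc(NC(=S)N/N=C/c4ccccc4)cc3F)ccnc2cc1OCCCN1CCCCC1` differs from compound 3 in one place: a group of 11 heavy atoms (8 carbon, 2 nitrogen, 1 sulfur; one six-membered aromatic ring of carbon only) in place of a group of 10 heavy atoms (6 carbon, 2 nitrogen, 1 oxygen, 1 sulfur; one five-membered aromatic ring with 1 hetero atom), on a nitrogen on an aromatic ring. Within the data shown here, no measured pair shows what such a change does in this assay, so the expectation rests on compound 3 alone. The step from compound 3 to compound 4 is expected to stay within the usual scatter, with no clear direction, so the estimated step is a 1.2-fold lower number from compound 3 to compound 4 (0.10 log units; within the scatter). For compound 4 the estimated result in this assay is 55000 nM, with an expected range from 18000 nM to 160000 nM, because compound 3 gives 68700 nM and nothing in the set argues for a move beyond the scatter.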

Compound 4, half-maximal inhibitory concentration: 78400 nM
Compound 4: middle estimate off by 1.4-fold (0.15 log units), on the low side; measured number inside the range.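

Going by these compounds alone, the exchange at a nitrogen on an aromatic ring gives a 1.1-fold higher number from compound 3 to compound 4 (0.06 log units; within the scatter) in this assay and provides the first step that can be read at this place. Within the data shown here, for this one pair, a six-membered aromatic ring of carbon only and the loss of the oxygen of the leaving group together leave the read-out within the scatter, although the single step cannot separate these two parts of the change. No supporting data bear on the reason for this result.

On these data alone, whether the same holds for other groups at this place remains open, for example a carboxylic acid or a dimethylamino group on the six-membered aromatic ring. A longer chain between that ring and the nitrogen is equally untested by the compounds shown here.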